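This account rests on a few compounds, and the source may have more. Where it says the series, first, only, none or still open, it means among the compounds named here.

Compounds measured so far in a functional assay on OCI-Ly7 cells (Homo sapiens) for antiproliferative activity, read by WST assay, with a stated time of 3 days; a lower number here means a stronger inhibitor, a higher number a weaker inhibitor:
Compound 1 `O=c1cc(I)n([C@@H]2O[C@H](CO)[C@@H](O)[C@H]2O)c(=O)[nH]1` gives > 50000 nM, which is a limit of the assay rather than a number.
Compound 2 `CN(C)c1cc(=O)[nH]c(=O)n1[C@@H]1O[C@H](CO)[C@@H](O)[C@H]1O` gives > 50000 nM, likewise a limit of the assay.

Among the measured compounds shown here, compound 2 therefore stands only at a limit in this assay, and the single measured step, a step that the two limits leave unreadable from compound 1 to compound 2, cannot be read, since both ends sit at the limit of > 50000 nM in this assay, at which 2 of the 2 values shown sit. The next change is formyl in place of dimethylamino on an aromatic carbon, giving compound 3 `O=Cc1cc(=O)[nH]c(=O)n1[C@@H]1O[C@H](CO)[C@@H](O)[C@H]1O`. For the measured compounds named here, no measured step bears on this change: the one step available does not show whether swapping the group on that aromatic carbon moves potency at all. With both neighbours at the limit, nothing points toward compound 3 becoming a readable inhibitor. Compound 3 is therefore expected to stay near the limit as well, at an estimated 60000 nM with a range from 20000 nM to 200000 nM. This estimate means a step that the limit leaves unreadable from compound 2 to compound 3, though that step is itself not expected to be readable.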

Compound 3, half-maximal inhibitory concentration: > 50000 nM
Compound 3 gave a limit, no number; the forecaster's own chance of this, stated with the estimate: 80%; the middle value lies beyond the limit too.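

Compound 3 also gives only a limit of the assay, so neither its step from compound 1 nor its step from compound 2 can be read: the limit of > 50000 nM in this assay, at which 3 of the 3 values shown sit.

The compounds shown leave open whether any group on that aromatic carbon can give a readable potency.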